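Moving one methoxy group: compound 3 to compound 4

The source may report more compounds than this note shows. Statements on the series, on what has been measured and on what is new or still open speak of the compounds shown alone.

Measured in an ADME assay on SH-SY5Y cells (Homo sapiens) for cytotoxicity, read by MTT assay, with a stated time of 72 h (on this read-out higher numbers stand for weaker inhibition and lower numbers for stronger inhibition), so far:
- compound 1 `COc1ccc(C(=O)N2CCN(CC(=O)N3CCN(CCCc4c[nH]c5ccccc45)CC3)CC2)cc1` gives 148000 nM
- compound 2 `COc1ccc(C(=O)N2CCN(CC(=O)N3CCN(CCCc4c[nH]c5ccc(F)cc45)CC3)CC2)cc1` gives 161000 nM
- compound 3 `COc1ccc(C(=O)N2CCN(CC(=O)N3CCN(CCCc4c[nH]c5ccc(OC)cc45)CC3)CC2)cc1` gives 190000 nM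

Compound 3 stands within the scatter of both other compounds. Compound 4 `COc1cccc(C(=O)N2CCN(CC(=O)N3CCN(CCCc4c[nH]c5ccc(OC)cc45)CC3)CC2)c1` differs from it by 3-methoxyphenyl in place of 4-methoxyphenyl on a carbonyl carbon which is 3-methoxyphenyl in place of 4-methoxyphenyl on a carbonyl carbon. The measured steps are a 1.1-fold higher number from compound 1 to compound 2 (0.04 log units; within the scatter) and a 1.3-fold higher number from compound 1 to compound 3 (0.11 log units; within the scatter) and a 1.2-fold higher number from compound 2 to compound 3 (0.07 log units; within the scatter) and none of them touches the group on that carbonyl carbon. They offer only indirect guidance, and all are small. In this assay the expected change is a 1.1-fold lower number from compound 3 to compound 4 (0.04 log units; within the scatter) and no step beyond the scatter is expected. Compound 4 is estimated at 175000 nM with an expected range from 100000 nM to 300000 nM in this read-out.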

Compound 4, half-maximal inhibitory concentration: > 200000 nM
Compound 4 gave a limit, no number; the forecaster's own chance of this, stated with the estimate: 10%; at least 1.1-fold (0.05 log units) between middle value and limit.
By their numbers in this assay, from the lowest: compounds 1, 2 and 3 (each within the scatter of the next). At a limit, above all of these: compound 4.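

In this assay compound 4 gives a limit, not a number: > 200000 nM. The exchange of 4-methoxyphenyl for 3-methoxyphenyl on the carbonyl carbon, the only change shown at this place, gives an at least 1.0-fold higher number from compound 3 to compound 4 (0.02 log units; that floor lies within the scatter), so it does not bring the reading down, but its true size stays unknown. This limit is reached only once in the series: the limit of > 200000 nM in this assay, at which 1 of the 4 values shown sits.

As far as these compounds go, how the read-out would respond to an amine or a carboxylic acid in place of the methoxy group remains open. So does the effect of an unsubstituted phenyl on that carbonyl carbon.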